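The source may hold more compounds than are shown below. What is called first, only, known or untested is meant among the compounds shown, and "the series" means these compounds.

Compounds measured so far:

Compound 1, `O=Cc1ccc(-c2cnc(C(=O)CCCCCCc3ccccc3)o2)nc1`, gives 2.2 nM in an assay for inhibition of Fatty-acid amide hydrolase 1 (Rattus norvegicus), using a Dixon plot; on this read-out higher numbers stand for weaker inhibition and lower numbers for stronger inhibition.
Compound 2, `O=C(CCCCCCc1ccccc1)c1ncc(-c2ccc(CCl)cn2)o1`, gives 22.4 nM in this assay.
Compound 3, `O=CCCCCc1cnc(C(=O)CCCCCCc2ccccc2)o1`, gives 14.6 nM in this assay.

Compound 2 holds the highest of the three numbers. Its nearest neighbour is compound 3, and the gap a 1.5-fold lower number from compound 2 to compound 3 (0.19 log units; within the scatter) lies within the scatter, so the two cannot be ranked against each other. Its furthest neighbour is compound 1, separated by a 10-fold higher number from compound 1 to compound 2 (1.01 log units; beyond the scatter), which lies beyond the scatter.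

Compound 4, `O=C(CCCCCCc1ccccc1)c1ncc(CCCCCCl)o1`, is the next compound to be measured. It differs from compound 2 in one place: a group of 6 heavy atoms (5 carbon, 1 chlorine; no ring) in place of a group of 8 heavy atoms (6 carbon, 1 nitrogen, 1 chlorine; one six-membered aromatic ring with 1 hetero atom), on an aromatic carbon.

Among the measured compounds shown here, the step that bears most directly on this change is the one from compound 2 to compound 3, where a ring group on the same aromatic carbon gave way to a chain group of comparable size and the result, a 1.5-fold lower number from compound 2 to compound 3 (0.19 log units; within the scatter), stayed within the scatter. The step of a 6.6-fold higher number from compound 1 to compound 3 (0.82 log units; beyond the scatter) is the same kind of ring-to-chain exchange, but it starts from compound 1 and so does not describe compound 2. On this basis compound 4 is expected to sit close to compound 2, with a step of a 1.2-fold lower number from compound 2 to compound 4 (0.09 log units; within the scatter) that may not rise beyond the scatter. The estimate for compound 4 in this assay is 18 nM, with a range from 7 nM to 45 nM.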

Compound 4, inhibition constant: 5.2 nM
For compound 4 the middle estimate is 3.5-fold (0.54 log units) above the measured one, outside the stated range (below it).
By their numbers in this assay, from the lowest: compound 1; then compound 4; then compounds 3 and 2 (each within the scatter of the next).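

On the aromatic carbon next to the ring oxygen, the ring group does not give way to a chain without consequence in this assay: the 5-chloropentyl chain brings a step beyond the scatter (a 4.3-fold lower number from compound 2 to compound 4 (0.63 log units; beyond the scatter)), which the formyl-ended chain did not (the step from the ring group in the earlier pair stayed within it). The end of the group also matters in a way that depends on what carries it, since chloromethyl in place of formyl lowers the number on the chain (a 2.8-fold lower number from compound 3 to compound 4 (0.45 log units; beyond the scatter)) but raises it on the ring (a 10-fold higher number from compound 1 to compound 2 (1.01 log units; beyond the scatter)). The chain still does not match the formyl-bearing ring group (a 2.4-fold higher number from compound 1 to compound 4 (0.37 log units; beyond the scatter)).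

Nothing at hand explains this change of direction. The compounds shown leave open whether a chain ending in an amine or a carboxylic acid, or a longer chain carrying chlorine, would follow compound 4.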